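Moving the chlorine around the aryl ring of compound 1

The source may hold more compounds than are shown below. What is called first, only, known or untested is meant among the compounds shown, and "the series" means these compounds.

Measured compounds:
- compound 1 `Cc1nc(-c2ccc(Cl)cc2)sc1C(=O)CSc1nc(-c2cccc(Cl)c2)c(C#N)c(=O)[nH]1`: 52.6%
- compound 2 `Cc1nc(-c2ccccc2)sc1C(=O)CSc1nc(-c2cccc(Cl)c2)c(C#N)c(=O)[nH]1`: 50.6%
- compound 3 `Cc1nc(-c2ccccc2)sc1C(=O)CSc1nc(N)c(C#N)c(-c2ccccc2)n1`: 26.3%

In a functional assay on U-87MG ATCC cells for antiproliferative activity against U-87 MG (Homo sapiens), read by MTT assay, with a stated time of 48 h, tested at 50 uM (on this read-out higher numbers stand for a weaker effect at the one concentration tested and lower numbers for a stronger effect), compound 1 gives 52.6%. Compound 2 sits close to it, and the step of a number 2 percentage points lower from compound 1 to compound 2 (within the scatter) says the two cannot be told apart. Compound 3, which carries a different core, gives 26.3%, a number well beyond the scatter away from compound 1.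

The unmeasured compound 4 `Cc1nc(-c2ccc(Cl)cc2)sc1C(=O)CSc1nc(-c2ccc(Cl)cc2)c(C#N)c(=O)[nH]1` keeps the core of compound 1 and differs only in the aryl group on that core: 4-chlorophenyl in place of 3-chlorophenyl on an aromatic carbon. No measured step touches this aryl group; the only step shown, that from compound 1 to compound 2, concerns the other aryl ring and lies within the scatter. Nothing in the numbers therefore points to a change of size beyond the scatter in this assay in either direction. Compound 4 is expected to give about 52%, with a range from 40% to 64%. The step of a number 0.6 percentage points lower from compound 1 to compound 4 (within the scatter) that this estimate implies is expected to lie within the scatter.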

Compound 4, a percentage reported as activity, at one concentration (the size of the read-out at that concentration, not a potency): 60%
For compound 4 the middle estimate is 8 percentage points below the measured one; the range from low to high includes it.
By their numbers in this assay, from the lowest: compound 3; then compounds 2, 1 and 4 (each within the scatter of the next).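

In this assay the change from 3-chlorophenyl to 4-chlorophenyl on the shared core gives a number 7.4 percentage points higher from compound 1 to compound 4 (within the scatter) and so does not separate the two compounds. Within the data shown here, this is the first view of this position, where the aryl group sits next to the ring nitrogen and ortho to the cyano group, and moving the chlorine within that group leaves no readable difference in this read-out. No independent evidence bears on this result.

The compounds shown keep a chlorophenyl group at this position in the shared core, so they leave open whether an unsubstituted phenyl, a methoxyphenyl or an aminophenyl would give a step beyond the scatter. They also leave open whether replacing the aryl group with a small amine or a carboxylic acid would matter here.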